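Mirror-Image Pair of the Fully Methylated Hydroxyl Analogue

This account rests on a few compounds, and the source may have more. Where it says the series, first, only, none or still open, it means among the compounds named here.

compound 1 `COc1cc(C(c2ccc(O)c(OC)c2)[C@H](C)[C@H](C)CF)ccc1O`: 75000 nM
compound 2 `COc1ccc(C(c2ccc(OC)c(OC)c2)[C@H](C)[C@H](C)CO)cc1OC`: > 100000 nM
compound 3 `COc1cc(C(c2ccc(O)c(OC)c2)[C@@H](C)[C@@H](C)CF)ccc1O`: 42000 nM

In a functional assay on HeLa cells (Homo sapiens) for cytotoxicity, read by WST assay, with a stated time of 48 h (on this read-out higher numbers stand for weaker inhibition and lower numbers for stronger inhibition), compound 1 gives 75000 nM and compound 3 gives 42000 nM, so the step of a 1.8-fold lower number from compound 1 to compound 3 (0.25 log units; within the scatter). Compound 2 is reported in this assay only as > 100000 nM, a limit and not a number, as the limit of > 100000 nM in this assay, at which 1 of the 3 values shown sits, states.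

Compound 4 `COc1ccc(C(c2ccc(OC)c(OC)c2)[C@@H](C)[C@@H](C)CO)cc1OC` differs from compound 2 as follows: the two compounds have the same atoms and bonds and differ only in configuration as drawn: 2 of 2 stereo elements differ (all stereocentres are inverted: mirror images); a stereocentre at a saturated chain carbon is drawn S in compound 2 and R in compound 4; a stereocentre at a saturated chain carbon is drawn S in compound 2 and R in compound 4. For the measured compounds named here, the one measured step that bears on this is a 1.8-fold lower number from compound 1 to compound 3 (0.25 log units; within the scatter), a pair related in the same way, as the fact that compounds 1 and 3 differ only in the configuration as drawn records, and it stayed within the scatter. A step that the limit leaves unreadable from compound 2 to compound 4 is therefore expected, with no change beyond the scatter. Compound 4 is estimated at 150000 nM, between 70000 nM and 400000 nM, most probably again reported only as a limit.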

Compound 4, half-maximal inhibitory concentration: > 100000 nM
Compound 4: only a limit was reported (the forecaster's own chance of this, stated with the estimate: 80%); the middle value does not contradict the limit.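

Compound 2 and compound 4 are both reported in this assay only as limits, so no step can be read between these mirror images. The compounds shown leave open whether configuration changes the read-out for this pair.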